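From benzyl to 3,4-dinitrophenyl on compound 2

The source may hold more compounds than are shown below. What is called first, only, known or untested is meant among the compounds shown, and "the series" means these compounds.

In an ADME assay on HEK-293T cells (Homo sapiens) for cytotoxicity, read by CCK-8 assay, with a stated time of 48 h (a higher number here means a weaker inhibitor, a lower number a stronger inhibitor), compound 2 (`COc1cccc(NC(=O)NCCNS(=O)(=O)c2ccc(-c3ccccc3OCc3ccccc3)s2)c1`) gives > 20000 nM as a limit, not a number, and so stands at the limit of > 20000 nM in this assay, at which 2 of the 3 values shown sit, with one other compound. Compound 4 (`COc1cccc(NC(=O)NCCNS(=O)(=O)c2ccc(-c3ccccc3Oc3ccc([N+](=O)[O-])c([N+](=O)[O-])c3)s2)c1`) differs from it by 3,4-dinitrophenyl in place of benzyl on an oxygen on an aromatic ring in one place: 3,4-dinitrophenyl in place of benzyl on an oxygen on an aromatic ring. Within the data shown here, no measured step makes this exact change. Compound 1 (`O=C(NCCNS(=O)(=O)c1ccc(-c2ccccc2Oc2ccc([N+](=O)[O-])c([N+](=O)[O-])c2)s1)Nc1cc(Cl)cc(Cl)c1`) also carries 3,4-dinitrophenyl and gives > 20000 nM as a limit, which makes it the nearest guide. Compound 3 (`O=S(=O)(NCCNC(=S)Nc1ccc(Cl)cc1)c1ccc(-c2ccccc2OCc2ccccc2)s1`) gives 12100 nM in this test. Among the measured compounds shown here, the one measured step is an at least 1.6-fold lower number from compound 2 to compound 3 (0.21 log units; that floor lies within the scatter) and it concerns a different group. The expected step that the limit leaves unreadable from compound 2 to compound 4 is therefore no move beyond the scatter. In this assay compound 4 is estimated at 22000 nM within an expected range from 10000 nM to 40000 nM for now.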

Compound 4, half-maximal inhibitory concentration: 17800 nM
Compound 4: middle estimate off by 1.2-fold (0.09 log units), on the high side, and the stated range covers the measured number.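

In this assay, compound 4 shows that 3,4-dinitrophenyl on this oxygen can go with a readable number, which compound 1 did not give. Putting it in place of benzyl gives an at least 1.1-fold lower number from compound 2 to compound 4 (0.05 log units; that floor lies within the scatter), and putting 3-methoxyphenyl in place of 3,5-dichlorophenyl gives an at least 1.1-fold lower number from compound 1 to compound 4 (0.05 log units; that floor lies within the scatter). Neither floor shows a move beyond the scatter, and only floors can be stated since compound 2 stands at a limit: the limit of > 20000 nM in this assay, at which 2 of the 4 values shown sit.

From the compounds shown here alone, the full size of both steps remains open. So does how a plain phenyl or a methyl on this oxygen would read.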